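Ring-size change at the amidine-bearing position of compound 1

The source may hold more compounds than are shown below. What is called first, only, known or untested is meant among the compounds shown, and "the series" means these compounds.

Measured so far:
compound 1, `COc1ccc(Br)cc1CCc1ccccc1C1=NCCN1`: 450 nM
compound 2, `COc1ccc(Br)cc1CSc1ccccc1C1=NCCCN1`: 270 nM

Among the compounds with values here, in a functional assay for antagonist activity, with Mus musculus as the target, read by cAMP accumulation (a lower number here means a stronger inhibitor, a higher number a weaker inhibitor), compound 1 gives 450 nM, the higher of the two numbers measured so far. Compound 2 gives 270 nM; the two values lie within the usual scatter of each other, so they say nothing about an order between the two compounds. Compound 2 also differs from compound 1 in more than one place, so no single structural cause can be read from that pair.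

Compound 3, `COc1ccc(Br)cc1CCc1ccccc1C1=NCCCN1`, is not yet measured. It differs from compound 1 as follows: a group of 6 heavy atoms (4 carbon, 2 nitrogen; one six-membered non-aromatic ring with 2 hetero atoms) in place of a group of 5 heavy atoms (3 carbon, 2 nitrogen; one five-membered non-aromatic ring with 2 hetero atoms), on an aromatic carbon. Within the data shown here, the only other compound carrying the six-membered ring is compound 2, whose value is within the scatter of compound 1, and that comparison is confounded by the second difference.

For compound 3 a step of no more than the scatter is expected in this assay , in either direction, with a 1.3-fold lower number from compound 1 to compound 3 (0.11 log units; within the scatter) as the estimated change. Compound 3 is expected to give about 350 nM, plausibly between 150 nM and 900 nM.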

Compound 3, half-maximal inhibitory concentration: 280 nM
Compound 3: middle estimate off by 1.3-fold (0.10 log units), on the high side; low and high end bracket the measured number.
By their numbers in this assay, from the lowest: compounds 2, 3 and 1 (each within the scatter of the next).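

Working notes on the ring at this position. In this assay, the six-membered non-aromatic ring with 2 hetero atoms replaces the five-membered one as the only difference, on an aromatic carbon ortho to a large group, something the pair of compound 1 and compound 2 could not show, as those two differ in more than one place. The change gives a 1.6-fold lower number from compound 1 to compound 3 (0.21 log units; within the scatter), so the two rings cannot be ordered here, and going from the five-membered to the six-membered ring has no readable effect on the number in this assay. No measurement is available that would bear on the reason for this result.

As far as these compounds go, this reading rests on a single matched pair, so it remains open whether the same ring change would also stay within the scatter on the core of compound 2. From the compounds shown here alone, it also remains open whether a seven-membered ring, an open-chain amidine, a primary amine or a carboxylic acid on this aromatic carbon would move the number beyond the scatter.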